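The source may hold more compounds than are shown below. What is called first, only, known or untested is meant among the compounds shown, and "the series" means these compounds.

Measured so far:
- compound 1 `CC(C)N1C(=O)COc2ccc(-c3cnc(Cl)c(NS(=O)(=O)c4ccc(F)cc4)c3)cc21`: 21500 nM
- compound 2 `COc1cccc(N2C(=O)COc3ccc(-c4cccc(NS(=O)(=O)c5ccc(F)cc5)c4)cc32)c1`: > 40000 nM (a limit of the assay, not a number)

Going by the values given here, in a functional assay on HepG2 cells (Homo sapiens) for antiproliferative activity, read by MTT assay, with a stated time of 72 h (a lower number here means a stronger inhibitor, a higher number a weaker inhibitor), compound 1 gives 21500 nM as the only actual number so far. Compound 2 is reported only as a limit, > 40000 nM, and not as a number. Compound 1 therefore has no measured neighbour to be ranked against, and the two compounds also differ in more than one place.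

Compound 3 `O=C1COc2ccc(-c3cnc(Cl)c(NS(=O)(=O)c4ccc(F)cc4)c3)cc2N1c1ccccc1` keeps the core of compound 1 but has phenyl in place of isopropyl on an amide-type nitrogen in a ring. Among the compounds with values here, no measured step shows what this change does in this assay, so no shift beyond the usual scatter is expected. Compound 2 stands at the limit of > 40000 nM in this assay, at which 1 of the 2 values shown sits, and this tilts the expectation slightly towards a weaker value.

The estimated change is a 1.2-fold higher number from compound 1 to compound 3 (0.08 log units; within the scatter), which stays within the scatter. For compound 3 the expected value is 26000 nM, with an estimated range from 10000 nM to 40000 nM.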

Compound 3, half-maximal inhibitory concentration: 35700 nM
Beside the measured number, compound 3's estimate is 1.4-fold (0.14 log units) below it; measured number inside the range.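

In this assay, going by these compounds alone, this is the first readable step at this position: phenyl in place of isopropyl on the amide-type nitrogen in the ring gives a 1.7-fold higher number from compound 1 to compound 3 (0.22 log units; within the scatter) and thus stays within the scatter. The group at this nitrogen goes from isopropyl, with no ring, to a six-membered aromatic ring of carbon only, and in this one pair that exchange brings no clear gain or loss. Compound 2 also carries a ring on this nitrogen, but it differs from the other two in more than one place, and its reading is a limit of the assay, not a number: the limit of > 40000 nM in this assay, at which 1 of the 3 values shown sits.

On these data alone, whether a methyl group, a plain hydrogen or a longer chain ending in an amine or a carboxylic acid on this nitrogen would shift the number beyond the scatter remains open. This single pair also cannot tell whether phenyl and isopropyl would stay as close if another part of the shared core were different.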